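Lipophilicity notes: a urea series, from compound 2 to compound 4

This account rests on a few compounds, and the source may have more. Where it says the series, first, only, none or still open, it means among the compounds named here.

Measured so far:
- compound 1, `CCOC(=O)C1=C(C)NC(=S)NC1c1cn(C(=O)CNc2ccccc2Cl)c2ccccc12`: 3.44
- compound 2, `CCOC(=O)C1=C(C)NC(=O)NC1c1cn(C(=O)CNc2ccc([N+](=O)[O-])cc2C)c2ccccc12`: 1.94
- compound 3, `CCOC(=O)C1=C(C)NC(=S)NC1c1cn(C(=O)CNc2cccc([N+](=O)[O-])c2)c2ccccc12`: 2.88

In a physicochemical assay for lipophilicity (on this read-out lower numbers stand for lower lipophilicity and higher numbers for higher lipophilicity), compound 2 stands lowest of the three numbers. Its nearest neighbour is compound 3, which gives 2.88; the furthest is compound 1, which gives 3.44, and both gaps are beyond the scatter. Compound 2 is also the only one of the three that carries the oxo core, the other two carrying the thio core, so its standing rests on that difference as much as on the aryl group.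

The unmeasured compound 4, `CCOC(=O)C1=C(C)NC(=O)NC1c1cn(C(=O)CNc2ccccc2N)c2ccccc12`, differs from compound 2 in one place:

2-aminophenyl in place of 2-methyl-4-nitrophenyl on an amine nitrogen

Going by the values given here, no measured pair repeats this exact change. Among the compounds with values here, the only step among the measured compounds that alters the aryl group on the amine nitrogen is a number 0.56 log units lower from compound 1 to compound 3 (beyond the scatter), and that exchange shares no group with the present one. Within the data shown here, it shows only that exchanging this aryl group can move this assay by a modest amount. The present change removes the nitro and methyl groups and adds an amino group, a larger reshaping of the aryl, so a downward step larger than that modest one is expected.

Compound 4 is therefore estimated at 0.9 in this assay, within 0.3 to 1.5, an expected step of a number 1.04 log units lower from compound 2 to compound 4 (beyond the scatter).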

Compound 4, partition coefficient: 0.74
The estimate for compound 4 lay 0.16 log units above the measured number; the range from low to high includes it.
By their numbers in this assay, from the lowest: compound 4; then compound 2; then compound 3; then compound 1.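

In this assay, 2-aminophenyl in place of 2-methyl-4-nitrophenyl on an amine nitrogen gives a number 1.20 log units lower from compound 2 to compound 4 (beyond the scatter), a large step and the first aryl exchange read at this position on the core shared by compound 2 and compound 4. Going by these compounds alone, the only earlier exchange at this nitrogen, a number 0.56 log units lower from compound 1 to compound 3 (beyond the scatter), is modest and sits on the core of compound 1, so the position is now seen to carry both a modest and a large step, on two different cores and with different aryl groups. Nothing on hand gives a reason for the size of the new step.

Still open, going by these compounds, is how the step divides among the loss of the nitro group, the loss of the methyl group and the arrival of the amino group, since all three travel together in this one exchange. Also open, on these data alone, are where a hydroxyl or a carboxylic acid in place of the amino group would fall in this assay, and whether 2-aminophenyl would give a step of similar size on the core of compound 1.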